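A few compounds are considered here, and "the series" means these few. Any claim that something is new, unique, unknown or untested is made for them only; others in the source may bear on it.

The study concerns a small set of sulfonylhydrazones on a shared core, all tested in an assay on isolated protein for inhibition of phosphatidylinositol 4,5-bisphosphate 3-kinase catalytic subunit beta isoform (Homo sapiens), read by 33P incorporation, with a stated time of 60 min; on this read-out higher numbers stand for weaker inhibition and lower numbers for stronger inhibition. Compound 1 `Cc1ccc([N+](=O)[O-])cc1S(=O)(=O)N(C)/N=C/c1cnn2cccc(Br)c12` is reported only as a limit of the assay: in this assay compound 1 gives > 1000 nM. Compound 2 `Cc1ccc([N+](=O)[O-])cc1S(=O)(=O)N(C)/N=C/c1cnn2c(C)cccc12` likewise reaches only a limit, and in this assay compound 2 gives > 1000 nM. Going by the values given here, compound 3 `Cc1ccc([N+](=O)[O-])cc1S(=O)(=O)N(C)/N=C/c1cnn2ccc(Cl)cc12` is the single member with a numerical result; in this assay compound 3 gives 390 nM, so it stands as the only number among the three. Compound 1 and compound 2 together account for (the limit of > 1000 nM in this assay, at which 2 of the 3 values shown sit).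

Compound 4 `Cc1ccc([N+](=O)[O-])cc1S(=O)(=O)N(C)/N=C/c1cnn2ccc(C(=O)N(C)C)cc12` has not yet been measured. It differs from compound 3 in one place: dimethylcarbamoyl in place of chloro on an aromatic carbon, which is dimethylcarbamoyl in place of chloro on an aromatic carbon of a six-membered aromatic ring with one nitrogen, meta to a fused ring, opposite the ring nitrogen and para to a fused ring. Among the compounds with values here, no step between two measured compounds is available, so nothing in the data shows how a change on that carbon moves the read-out; the expectation rests on the value of compound 3 alone. The author expects a step of a 1.0-fold higher number from compound 3 to compound 4 (0.01 log units; within the scatter), that is, none beyond the scatter. Compound 4 is accordingly estimated at 400 nM, with a range from 100 nM to 2000 nM.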

Compound 4, half-maximal inhibitory concentration: > 1000 nM
Compound 4 gave a limit, no number (the forecaster's own chance of this, stated with the estimate: 30%); at least 2.5-fold (0.39 log units) between middle value and limit.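

Going by these compounds alone, on this aromatic carbon, opposite the ring nitrogen and para to a fused ring, dimethylcarbamoyl in place of chloro gives an at least 2.5-fold higher number from compound 3 to compound 4 (0.40 log units; beyond the scatter), the first step at this position, so the read-out in this assay clearly depends on the group placed there. Going by these compounds, compound 4 stands at a limit of the assay and not at a number, so the step gives only a lower bound, and how far inhibition falls beyond it remains unknown. Compound 3 thus remains the only member of the set with a numerical result, and the limit now accounts for all the others: the limit of > 1000 nM in this assay, at which 3 of the 4 values shown sit.

The compounds shown do not tell whether the carbonyl or the methyl groups of dimethylcarbamoyl go with the higher number, nor do they show any cause for the step. A primary amide, a methoxy group, a fluoro or a methyl group on the same carbon would show whether chloro is unusual here or whether other small groups give a measurable number as well.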